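The compounds below may be only part of what the source reports. "The series", "measured", "known", "first", "only" and "open" are said of these compounds alone.

Compound 1, `CN(C(=O)NC(=O)c1ccccc1F)c1nc(C(F)(F)F)c(C(=O)N/N=C/c2cc(C(F)(F)F)cc(C(F)(F)F)c2)s1`: 5.43 ug/mL
Compound 2, `CN(C(=O)NC(=O)c1cccc(C(F)(F)F)c1)c1nc(C(F)(F)F)c(C(=O)N/N=C/c2cc(C(F)(F)F)cc(C(F)(F)F)c2)s1`: 8.2 ug/mL

Both were tested in a functional assay on A549 cells (Homo sapiens) for inhibition, read by MTT assay, with a stated time of 72 h; on this read-out higher numbers stand for weaker inhibition and lower numbers for stronger inhibition. Going by the values given here, compound 2 carries the higher of the two numbers, yet its only neighbour is compound 1, and the single measured step, a 1.5-fold higher number from compound 1 to compound 2 (0.18 log units; within the scatter), is within the scatter, so the two compounds cannot be put in order on what has been seen.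

Compound 3, `CN(C(=O)NC(=O)c1ccc(C(F)(F)F)cc1)c1nc(C(F)(F)F)c(C(=O)N/N=C/c2cc(C(F)(F)F)cc(C(F)(F)F)c2)s1`, differs from compound 2 in one place: 4-(trifluoromethyl)phenyl in place of 3-(trifluoromethyl)phenyl on a carbonyl carbon. The two compounds share every atom and differ only in how those atoms are joined. Among the compounds with values here, the one measured step concerns a different exchange of aryl groups and was itself within the scatter, so it gives little reason to expect movement here. The step expected in this assay is therefore a 1.0-fold lower number from compound 2 to compound 3 (0.01 log units; within the scatter), not beyond the scatter in either direction. Compound 3 is estimated at 8 ug/mL, with a range from 4 ug/mL to 16 ug/mL.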

Compound 3, half-maximal inhibitory concentration: 5.9 ug/mL
For compound 3 the middle estimate is 1.4-fold (0.13 log units) above the measured one; measured number inside the range.
By their numbers in this assay, from the lowest: compounds 1, 3 and 2 (each within the scatter of the next).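

In this assay the exchange of 3-(trifluoromethyl)phenyl for 4-(trifluoromethyl)phenyl on the carbonyl carbon gives a 1.4-fold lower number from compound 2 to compound 3 (0.14 log units; within the scatter) and so shows that rejoining the same atoms in this way has no effect that can be read here. The exchange of 2-fluorophenyl for 4-(trifluoromethyl)phenyl at the same place gives a 1.1-fold higher number from compound 1 to compound 3 (0.04 log units; within the scatter) and adds a second result of this kind, so the three aryl groups seen so far cannot be told apart at this position. No measurement is available that would help to explain this result.

From the compounds shown here alone, all three compounds carry a substituted phenyl on this carbonyl carbon, so it stays open whether a longer alkyl chain, or a phenyl bearing an amine or a carboxylic acid, would move the number beyond the scatter. The shared core is the same in all three, so these compounds also leave open how the number responds to changes elsewhere in the molecule.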